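Benzyl Replaces Bromine on a Urea-Linked Nucleoside

The source may report more compounds than this note shows. Statements on the series, on what has been measured and on what is new or still open speak of the compounds shown alone.

Compound 1, `Cc1cn([C@@H]2C[C@H](O)[C@@H](CNC(=O)Nc3ccc(Cl)cc3)O2)c(=O)[nH]c1=O`: in an ADME assay on MRC5 cells (Homo sapiens) for cytotoxicity (a higher number here means that more compound is tolerated, a lower number that less compound is tolerated), compound 1 gives > 50000 nM, which is a limit of the assay and not a number.
Compound 2, `Cc1cn([C@@H]2C[C@H](O)[C@@H](CNC(=O)Nc3ccc(Br)cc3)O2)c(=O)[nH]c1=O`: in this assay compound 2 gives > 50000 nM, again a limit rather than a number.
Compound 3, `Cc1cn([C@@H]2C[C@H](O)[C@@H](CNC(=O)Nc3cccc(COc4ccccc4)c3)O2)c(=O)[nH]c1=O`: in this assay compound 3 gives > 50000 nM, also a limit.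

Compound 2 thus stands at the top of what the assay can report, and so do the other two compounds, since all three values shown sit at the same limit (the limit of > 50000 nM in this assay, at which 3 of the 3 values shown sit). Among the measured compounds shown here, the only measured step, a step that the two limits leave unreadable from compound 1 to compound 2, cannot be read for the same reason: both of its ends are limits, so its size is unknown.

Compound 4, `Cc1cn([C@@H]2C[C@H](O)[C@@H](CNC(=O)Nc3ccc(Cc4ccccc4)cc3)O2)c(=O)[nH]c1=O`, differs from compound 2 by benzyl in place of bromo on an aromatic carbon. For the measured compounds named here, no measured step speaks directly to this change. What can be said is that compound 3, which carries a larger aromatic side piece than either halogen, still sits at the limit in this assay, which gives no sign that enlarging this part of the molecule lowers the tolerated concentration.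

Compound 4 is therefore expected to sit at the limit as well, with an estimated 60000 nM, between 30000 nM and 150000 nM. The expected step that the limit leaves unreadable from compound 2 to compound 4 is estimated to stay within the usual scatter.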

Compound 4, half-maximal cytotoxic concentration: > 50000 nM
Compound 4 gave a limit, no number; the forecaster's own chance of this, stated with the estimate: 85%; the middle value lies beyond the limit too.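

In this assay compound 4 gives > 50000 nM, again a limit and not a number, so the steps to it from compound 1 and compound 2 cannot be read. All the compounds shown stop at the same point: the limit of > 50000 nM in this assay, at which 4 of the 4 values shown sit.

What stays open is the concentration at which any of these compounds would harm the cells, and whether bromo, chloro and benzyl differ at all in this respect.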